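The source may hold more compounds than are shown below. What is called first, only, known or untested is meant among the compounds shown, and "the series" means these compounds.

Series so far:
- compound 1 `COc1ccc(-n2cc(-c3ccc(OC)c(OC)c3)nn2)c(OC)c1`: "not determined" (no result reported)
- compound 2 `COc1ccc(-n2cc(-c3ccc(O)c(OC)c3)nn2)c(OC)c1`: "not determined" (no result reported)
- compound 3 `COc1ccc(-n2cc(-c3cc(O)cc(O)c3)nn2)cc1O`: > 10000 nM

In a functional assay on MDA-MB-231 cells (Homo sapiens) for cytotoxicity, read by MTT assay (on this read-out higher numbers stand for weaker inhibition and lower numbers for stronger inhibition), compound 2 has no single number and stands as "not determined" (no result reported). Compound 1 gives no number either, with "not determined" (no result reported). Compound 3 gives > 10000 nM, which is a limit of the assay and not a number. That limit is the only quantitative anchor in the series: the limit of > 10000 nM in this assay, at which 1 of the 3 values shown sits.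

The next compound is compound 4 `COc1ccc(-n2cc(-c3ccc(O)c(OC)c3)nn2)cc1`. The structural change is hydrogen in place of methoxy on an aromatic carbon, ortho to a large group.

With no number for compound 2, no measured baseline exists for this step in this assay. No change beyond the usual scatter is expected, and no direction can be assigned. The estimate therefore leans on compound 3 with its > 10000 nM, and a result reported only as a limit is quite possible.

For compound 4 the expected value is about 12000 nM, with an estimated range of 2500 nM to 50000 nM.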

Compound 4, half-maximal inhibitory concentration: > 10000 nM
Compound 4: no number, only a limit (the forecaster's own chance of this, stated with the estimate: 50%); the middle value is on the limit's open side.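

In this assay compound 4 gives > 10000 nM, a limit of the assay and not a number. Within the data shown here, with no number for compound 2, no step to compound 4 can be read. The compounds shown leave open whether hydrogen in place of methoxy changes the read-out, and the series has only one quantitative anchor: the limit of > 10000 nM in this assay, at which 2 of the 4 values shown sit.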